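The compounds below may be only part of what the source reports. "The series", "measured", "known", "first", "only" and "open" are said of these compounds alone.

Compound 3 `N=C(N)c1ccc2oc(-c3ccc(OCCCCCCOc4ccccc4)cc3)cc2c1` gives 3300 nM in an ADME assay on L6 cells (Rattus norvegicus) for cytotoxicity, read by resazurin assay, with a stated time of 70 h; on this read-out higher numbers stand for weaker inhibition and lower numbers for stronger inhibition. Compound 1 `CC(C)NC(=N)c1ccc2oc(-c3ccc(OCCCCOc4ccccc4)cc3)cc2c1` gives 6900 nM. Compound 2 `CC(C)NC(=N)c1ccc2oc(-c3ccc(OCCCCCOc4ccccc4)cc3)cc2c1` gives 20500 nM.

Among these three, compound 3 has the lowest number, which on this read-out means the strongest inhibition of the rat cells: compound 1 stands next to it at a higher number, and compound 2 is furthest away, higher still. Compound 4 `CC(C)NC(=N)c1ccc2oc(-c3ccc(OCCCCCCOc4ccccc4)cc3)cc2c1` is the next member of the series and differs from compound 3 in one place: isopropyl in place of hydrogen on an amine nitrogen. For the measured compounds named here, compounds 1 and 2 both carry this isopropyl on the amine nitrogen, but each also carries a different chain between the two oxygens, so no measured step isolates the change from hydrogen to isopropyl. Going by the values given here, the only measured step, a 3.0-fold higher number from compound 1 to compound 2 (0.47 log units; beyond the scatter), concerns the chain and not the nitrogen, so it gives no direct guidance here. What remains is that both isopropyl-bearing compounds sit at higher numbers than compound 3. On that basis, a step of a 1.8-fold higher number from compound 3 to compound 4 (0.26 log units; within the scatter) toward weaker inhibition is expected for compound 4, with wide uncertainty. Compound 4 is therefore estimated at 6000 nM, within a range from 2500 nM to 15000 nM.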

Compound 4, half-maximal inhibitory concentration: 800 nM
For compound 4 the middle estimate is 7.5-fold (0.88 log units) above the measured one; measured number outside the range, below it.
By their numbers in this assay, from the lowest: compound 4; then compound 3; then compound 1; then compound 2.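

In this assay, the change from amino to isopropylamino can now be read directly: isopropyl in place of hydrogen on the amine nitrogen gives a 4.1-fold lower number from compound 3 to compound 4 (0.62 log units; beyond the scatter), so this swap moves toward stronger inhibition of the rat cells when the chain is held fixed. With the isopropylamino group kept in place, the chain can also be compared across the series: the longer chain of compound 4 gives a 26-fold lower number from compound 2 to compound 4 (1.41 log units; beyond the scatter) and an 8.6-fold lower number from compound 1 to compound 4 (0.94 log units; beyond the scatter), whereas the earlier lengthening gave a 3.0-fold higher number from compound 1 to compound 2 (0.47 log units; beyond the scatter), so compound 2 goes against any steady fall in the number as the chain grows. No measurement offered here explains either the effect of the isopropyl group or this uneven response to chain length.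

From the compounds shown here alone, it remains open whether the swap from amino to isopropylamino would lower the number in the same way on the shorter chains of compound 1 and compound 2. The compounds shown also leave open what an ethyl or cyclopentyl group on that nitrogen would do, or how a still longer chain would behave.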